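The compounds below may be only part of what the source reports. "The series", "measured", "known", "first", "only" and "open" are said of these compounds alone.

For the measured compounds named here, compound 3 `CSc1ccccc1OC(C)(C)C1OCC(C/C=C\CCC(=O)O)C(c2cccnc2)O1` gives 36 nM in an assay for inhibition of Thromboxane-A synthase (Homo sapiens), using microsomes (on this read-out lower numbers stand for stronger inhibition and higher numbers for weaker inhibition), the lowest of the three numbers so far, though the steps of a 1.4-fold lower number from compound 1 to compound 3 (0.15 log units; within the scatter) and a 1.3-fold lower number from compound 2 to compound 3 (0.10 log units; within the scatter) both lie within the scatter; compound 1 `CC(C)(Oc1ccc(F)cc1)C1OCC(C/C=C\CCC(=O)O)C(c2cccnc2)O1` gives 51 nM and compound 2 `CC(C)(Oc1ccccc1F)C1OCC(C/C=C\CCC(=O)O)C(c2cccnc2)O1` gives 45 nM in this assay. Compound 4 `CC(C)(Oc1ccccc1Br)C1OCC(C/C=C\CCC(=O)O)C(c2cccnc2)O1` differs from compound 3 by bromo in place of methylsulfanyl on an aromatic carbon, ortho to a large group. The step that bears on it is the earlier swap at the same aromatic carbon, a 1.3-fold lower number from compound 2 to compound 3 (0.10 log units; within the scatter), which stayed within the scatter, as did a 1.1-fold lower number from compound 1 to compound 2 (0.05 log units; within the scatter) on the phenyl group on the oxygen. For compound 4 the expected step is therefore a 1.1-fold higher number from compound 3 to compound 4 (0.05 log units; within the scatter), none beyond the scatter. Compound 4 is expected at 40 nM, in a range of 15 nM to 110 nM.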

Compound 4, half-maximal inhibitory concentration: 29 nM
Compound 4: the middle estimate sits 1.4-fold (0.14 log units) above what was measured; measured number inside the range.
By their numbers in this assay, from the lowest: compounds 4, 3, 2 and 1 (each within the scatter of the next).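

In this assay, bromo on this aromatic carbon, ortho to a large group, cannot be told apart from methylsulfanyl (a 1.2-fold lower number from compound 3 to compound 4 (0.09 log units; within the scatter)) or from fluoro (a 1.6-fold lower number from compound 2 to compound 4 (0.19 log units; within the scatter)), so three different groups at this place now lie within the scatter. The change from 4-fluorophenyl to 2-bromophenyl also stays within it (a 1.8-fold lower number from compound 1 to compound 4 (0.25 log units; within the scatter)). Nothing measured here gives a reason for this flat result. As far as these compounds go, it remains open whether an amine or a carboxylic acid on this carbon would leave the number equally unchanged.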